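The source may hold more compounds than are shown below. What is called first, only, known or untested is meant among the compounds shown, and "the series" means these compounds.

Compound 1 `O=C(O)c1ccccc1-c1ccc(CCc2ncc(CCC3CCCCC3)[nH]2)cc1` holds the lower of the two values known: in an in vitro functional assay on cells for agonist activity at Bombesin receptor subtype-3 (Mus musculus), read by luminescence and calcium flux (a higher number here means that more compound is needed for the effect, a lower number that less compound is needed), compound 1 gives 33 nM, whereas compound 2 `CCCCc1cnc(C(CCCO)Cc2ccc(-c3ccccc3C(=O)O)cc2)[nH]1` gives 238 nM in this assay, a gap beyond the usual scatter. Compound 3 `O=C(O)c1ccccc1-c1ccc(CCc2ncc(Cc3cccc(Cl)c3)[nH]2)cc1` keeps the core of compound 1 and differs from it in one place: 3-chlorophenyl in place of cyclohexylmethyl on a saturated chain carbon bound to an aromatic carbon. Among the compounds with values here, no step between measured compounds covers this change, so compound 3 is expected to need somewhat more compound than compound 1, with an estimated value in this assay of 100 nM, between 30 nM and 400 nM. That estimate means a step from compound 1 to compound 3 of a 3.0-fold higher number from compound 1 to compound 3 (0.48 log units; beyond the scatter), a modest loss.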

Compound 3, half-maximal effective concentration: 31 nM
Estimate against measurement, compound 3: 3.2-fold (0.51 log units) above, within the range that was stated.
By their numbers in this assay, from the lowest: compounds 3 and 1 (each within the scatter of the next); then compound 2.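

In this assay, 3-chlorophenyl in place of cyclohexylmethyl on a saturated chain carbon bound to an aromatic carbon gives a 1.1-fold lower number from compound 1 to compound 3 (0.03 log units; within the scatter) at this position. The earlier compounds shown here held no step at this place; this one shows that the aromatic ring with its chlorine and the non-aromatic ring of carbon are not told apart here. No measurement at hand accounts for this. Open, on these data alone, is whether the chlorine contributes at all: a plain phenyl would test that. Also open, as far as these compounds go, is how a methoxy group, an amine or a longer chain would fare here.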